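Swapping a Butoxy Chain for a Methylbenzyl Ether

A few compounds are considered here, and "the series" means these few. Any claim that something is new, unique, unknown or untested is made for them only; others in the source may bear on it.

Compound 1 `O=C(O)COc1cccc(NC(=O)c2ccc(Oc3ccccc3)cc2)c1`: > 10000 nM
Compound 2 `CCCCOc1cccc(C(=O)Nc2cccc(C(=O)O)c2)c1`: 3150 nM

Within the data shown here, in an assay on isolated protein for agonist activity at Bile acid receptor (Homo sapiens), read by TR-FRET, with a stated time of 3 h, in the absence of a further agent (on this read-out lower numbers stand for an effect already at smaller amounts and higher numbers for an effect only at larger amounts of compound), compound 2 gives 3150 nM, the only actual number among the values shown. Compound 1 sits at the limit of > 10000 nM in this assay, at which 1 of the 2 values shown sits, so its value is a limit and not a number. Compound 3 `Cc1ccc(COc2cccc(C(=O)Nc3cccc(C(=O)O)c3)c2)cc1` differs from compound 2 by 4-methylphenyl in place of propyl on a saturated chain carbon bound to an oxygen on an aromatic ring. Among the measured compounds shown here, no measured step of this kind exists here, so any expectation rests on the structural change alone. A modest move toward smaller amounts of compound is expected, with a 2.1-fold lower number from compound 2 to compound 3 (0.32 log units; beyond the scatter) as the estimated step. Compound 3 is therefore expected to give 1500 nM, within 300 nM to 8000 nM.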

Compound 3, half-maximal effective concentration: 1430 nM
Compound 3: middle estimate off by 1.0-fold (0.02 log units), on the high side; the measured number falls inside the stated range.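

Exchanging butoxy for (4-methylbenzyl)oxy gives a 2.2-fold lower number from compound 2 to compound 3 (0.34 log units; beyond the scatter) in this assay. This place on the chain therefore accepts a six-membered aromatic ring of carbon only, and the number moves to smaller amounts of compound rather than being lost. Nothing measured here bears on why the number moves.

On these data alone, whether the 4-methyl group itself matters remains open, as does the outcome with an unsubstituted benzyl, a 4-chlorobenzyl or a longer chain such as hexyl in this place.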